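Changing the aromatic substituent on the shared core of compound 3

The compounds below may be only part of what the source reports. "The series", "measured", "known", "first", "only" and "open" are said of these compounds alone.

Three compounds share one core and differ only in the aromatic group attached at one carbon of it. Compound 1 `Cc1csc(-c2cc(C(O)(C(F)(F)F)C(F)(F)F)cnc2N2CCN(S(=O)(=O)c3ccc(N)nc3)CC2)c1` gives 29 mL.min-1.g-1 in an ADME assay (liver) for metabolic stability, with Liver microsome (Homo sapiens) as the target, using microsomes and NADPH, with a stated time of 30 min, tested at 1 uM; a lower number here means slower removal, a higher number faster removal of the compound. Compound 2 `Nc1ccc(S(=O)(=O)N2CCN(c3ncc(C(O)(C(F)(F)F)C(F)(F)F)cc3-c3ccccc3O)CC2)cn1` gives 22 mL.min-1.g-1, and compound 3 `Nc1ccc(S(=O)(=O)N2CCN(c3ncc(C(O)(C(F)(F)F)C(F)(F)F)cc3-c3cnccc3F)CC2)cn1` gives 17 mL.min-1.g-1. Compound 3 sits at the low end of these three numbers, but the steps to it are small: a 1.7-fold lower number from compound 1 to compound 3 (0.23 log units; within the scatter) and a 1.3-fold lower number from compound 2 to compound 3 (0.11 log units; within the scatter), and likewise a 1.3-fold lower number from compound 1 to compound 2 (0.12 log units; within the scatter). None of these exchanges of the aromatic group moved the clearance beyond the scatter.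

Compound 4 `Nc1ccc(S(=O)(=O)N2CCN(c3ncc(C(O)(C(F)(F)F)C(F)(F)F)cc3-c3ccc4c(c3)CC(=O)N4)CC2)cn1` continues this series with a new group at the same carbon: a group of 10 heavy atoms (8 carbon, 1 nitrogen, 1 oxygen; one five-membered non-aromatic ring with 1 hetero atom, one six-membered aromatic ring of carbon only) in place of a group of 7 heavy atoms (5 carbon, 1 nitrogen, 1 fluorine; one six-membered aromatic ring with 1 hetero atom), on an aromatic carbon. The three measured steps all bear on this change, since each also swapped the aromatic group at this position, and each stayed within the scatter. The expectation is therefore a step of similar size, a 1.2-fold higher number from compound 3 to compound 4 (0.07 log units; within the scatter), not beyond the scatter. Compound 4 is estimated to give 20 mL.min-1.g-1, with a likely range from 10 mL.min-1.g-1 to 40 mL.min-1.g-1.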

Compound 4, intrinsic clearance in microsomes: < 14 mL.min-1.g-1
Compound 4: a limit, no number; the forecaster's own chance of this, stated with the estimate: 5%; middle value at least 1.4-fold (0.15 log units) from the limit.
By their numbers in this assay, from the lowest: compounds 3, 2 and 1 (each within the scatter of the next). At a limit, below all of these: compound 4.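

Compound 4 gives a limit of the assay rather than a number: the limit of < 14 mL.min-1.g-1 in this assay, at which 1 of the 4 values shown sits.

Even so, this is the first exchange at this carbon to go beyond the scatter, with an at least 2.0-fold lower number from compound 1 to compound 4 (0.31 log units; beyond the scatter), so the aromatic group here can shift clearance by more than the earlier swaps did. The other two steps are less decisive, with an at least 1.2-fold lower number from compound 3 to compound 4 (0.08 log units; that floor lies within the scatter) and an at least 1.5-fold lower number from compound 2 to compound 4 (0.19 log units; that floor lies within the scatter), so the new group of 10 heavy atoms cannot yet be separated from 4-fluoropyridin-3-yl or 2-hydroxyphenyl.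

Going by these compounds, how far the true value of compound 4 lies from its limit stays open. Also open, on these data alone, is how an amine or a carboxylic acid at this same carbon would behave in this assay.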